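Aryl sulfonyl swap on a nitro-indole hydrazone

The source may report more compounds than this note shows. Statements on the series, on what has been measured and on what is new or still open speak of the compounds shown alone.

Compound 1 `CN(C)/C=N/N=C/c1cn(S(=O)(=O)c2ccc(F)cc2)c2cccc([N+](=O)[O-])c12` gives 4970 nM in a functional assay on HEK293 cells for inhibition of 5-hydroxytryptamine receptor 6 (Homo sapiens), read by calcium flux and cAMP accumulation, with a stated time of 10 min (a lower number here means a stronger inhibitor, a higher number a weaker inhibitor), and compound 2 `Cc1ccc(S(=O)(=O)n2cc(/C=N/N=C/N(C)C)c3c([N+](=O)[O-])cccc32)cc1` gives 2120 nM, the lowest of the two numbers, with the step of a 2.3-fold lower number from compound 1 to compound 2 (0.37 log units; beyond the scatter) arising from methyl in place of fluoro on an aromatic carbon. Compound 3 `COc1ccc(Cl)cc1S(=O)(=O)n1cc(/C=N/N=C/N(C)C)c2c([N+](=O)[O-])cccc21` differs from compound 2 by 5-chloro-2-methoxyphenyl in place of 4-methylphenyl on a sulfonyl sulfur. Within the data shown here, the only step that bears on this change is a 2.3-fold lower number from compound 1 to compound 2 (0.37 log units; beyond the scatter), a modest shift from a single aryl substituent; a modest lowering is therefore expected for compound 3, a 2.1-fold lower number from compound 2 to compound 3 (0.33 log units; beyond the scatter). Compound 3 is estimated at 1000 nM, between 300 nM and 4000 nM.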

Compound 3, half-maximal inhibitory concentration: 2440 nM
Compound 3: middle estimate off by 2.4-fold (0.39 log units), on the low side; the range from low to high includes it.
By their numbers in this assay, from the lowest: compounds 2 and 3 (each within the scatter of the next); then compound 1.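

At the sulfonyl sulfur in this assay, 5-chloro-2-methoxyphenyl in place of 4-methylphenyl gives a 1.2-fold higher number from compound 2 to compound 3 (0.06 log units; within the scatter), so these two differently substituted aryl groups cannot be told apart. In place of 4-fluorophenyl, the same group gives a 2.0-fold lower number from compound 1 to compound 3 (0.31 log units; beyond the scatter), which leaves the 4-fluorophenyl compound apart from the other two. No evidence is available that bears on this result.

From the compounds shown here alone, whether the chloro or the methoxy alone would match the pair remains open. So does whether an amine or a carboxylic acid on this aryl ring would shift the number beyond the scatter.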